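Dichlorinated thiophene variant of a weak growth inhibitor

This account rests on a few compounds, and the source may have more. Where it says the series, first, only, none or still open, it means among the compounds named here.

Compound 1 `N=C(N)N/N=C/c1c(-c2cccs2)nc2n1CCS2` is the weakest of the three measured compounds in a functional assay on cells (Cancer cell lines, Homo sapiens) for inhibition (a lower number here means a stronger inhibitor of growth, a higher number a weaker inhibitor of growth), where compound 1 gives 28800 nM. Compound 2 `N=C(N)N/N=C/c1c(-c2cccs2)nc2sccn12` gives 12900 nM in the same assay, and compound 3 `Cc1cn2c(/C=N/Nc3ccccn3)c(-c3ccc(Cl)c([N+](=O)[O-])c3)nc2s1` gives 11500 nM; both of those numbers lie beyond the scatter from the value of compound 1. Compound 4 `N=C(N)N/N=C/c1c(-c2cc(Cl)sc2Cl)nc2n1CCS2` has not yet been measured. It differs from compound 1 by 2,5-dichlorothiophen-3-yl in place of thiophen-2-yl on an aromatic carbon. Within the data shown here, no measured pair shows this change, so its effect is unknown from the data. Compound 4 is expected to stay in the weak range, with a step of a 1.4-fold lower number from compound 1 to compound 4 (0.16 log units; within the scatter) that may not exceed the scatter. The estimate for compound 4 is 20000 nM, within 7000 nM to 60000 nM.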

Compound 4, concentration for 50% growth inhibition: 11200 nM
Beside the measured number, compound 4's estimate is 1.8-fold (0.25 log units) above it; the range from low to high includes it.
By their numbers in this assay, from the lowest: compounds 4, 3 and 2 (each within the scatter of the next); then compound 1.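

In this assay, among these compounds, 2,5-dichlorothiophen-3-yl in place of thiophen-2-yl gives a 2.6-fold lower number from compound 1 to compound 4 (0.41 log units; beyond the scatter), the first readable step at this position. The position therefore accepts the larger group, with its two chlorine atoms and shifted ring attachment, without losing growth inhibition, and the number moves modestly towards a stronger inhibitor. The compounds shown do not separate the effect of the chlorine atoms from that of the attachment point, which thiophen-3-yl without chlorine would address. Nothing available explains the step.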